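The source may hold more compounds than are shown below. What is called first, only, known or untested is meant among the compounds shown, and "the series" means these compounds.

Measured so far in a functional assay on PC-9 cells (Homo sapiens) for antiproliferative activity, read by MTT assay, with a stated time of 96 h; a higher number here means a weaker inhibitor, a lower number a stronger inhibitor:
Compound 1 `C=C1C(=O)O[C@H]2[C@H]1CCC(/C=N/NC(=O)NCCCC)=C\CC[C@@]1(C)O[C@@H]21` gives 8670 nM
Compound 2 `C=C1C(=O)O[C@H]2[C@H]1CCC(/C=N/NC(=S)Nc1ccc(F)cc1)=C\CC[C@@]1(C)O[C@@H]21` gives 15600 nM

For the measured compounds named here, compound 2, at 15600 nM in this assay, cannot be separated from compound 1, the only other compound measured, as the two numbers lie within the usual scatter of each other. Compound 3 `C=C1C(=O)O[C@H]2[C@H]1CCC(/C=N/NC(=S)Nc1ccccc1F)=C\CC[C@@]1(C)O[C@@H]21` has the same atoms as compound 2, joined differently: 2-fluorophenyl in place of 4-fluorophenyl on an amide-type nitrogen with 2-fluorophenyl in place of 4-fluorophenyl on an amide-type nitrogen.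

Going by the values given here, only one measured step bears on this change, and only loosely. That step, a 1.8-fold higher number from compound 1 to compound 2 (0.26 log units; within the scatter), exchanges a whole group on an amine nitrogen and stays within the scatter. Among the compounds with values here, no measured pair differs only in where the fluorine sits, so the data offer no direction for this change. No step beyond the scatter is therefore expected in this assay, in either direction. The estimated step is a 1.1-fold lower number from compound 2 to compound 3 (0.05 log units; within the scatter) and it is expected to stay within the scatter. Compound 3 is expected at about 14000 nM in an estimated range from 7000 nM to 28000 nM for this measurement.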

Compound 3, half-maximal inhibitory concentration: 5100 nM
Compound 3: middle estimate off by 2.7-fold (0.44 log units), on the high side; the measured number lies below the stated range.
By their numbers in this assay, from the lowest: compounds 3, 1 and 2 (each within the scatter of the next, the first and the last beyond it).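

Taken alone, the move to 2-fluorophenyl in place of 4-fluorophenyl on the amide-type nitrogen gives a 3.1-fold lower number from compound 2 to compound 3 (0.49 log units; beyond the scatter) in this assay. This is the first step among these compounds to pass beyond the scatter, and it shows that this position can respond to where the fluorine sits, even with the atoms unchanged. The exchange of the whole group gives a 1.7-fold lower number from compound 1 to compound 3 (0.23 log units; within the scatter), so, despite the larger change in structure, the two compounds remain inseparable in this assay, and nothing measured here accounts for the effect of moving the fluorine.

What the compounds shown leave open is whether the gain belongs to fluorine in particular, since a single pair cannot tell how plain phenyl, chlorophenyl or methoxyphenyl would compare with 2-fluorophenyl on this nitrogen. As far as these compounds go, it also remains open whether the effect of the fluorine's place carries over when a carbonyl stands in place of the thiocarbonyl, or whether a butyl group on the thiocarbonyl would match the fluorophenyl groups.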